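Aryl Exchange on the Shared Core: Toward Compound 4

The source may report more compounds than this note shows. Statements on the series, on what has been measured and on what is new or still open speak of the compounds shown alone.

Compound 1, `Brc1cn2ccnc2c(-c2ccc3ncn(C4CCCCC4)c3c2)n1`: 21.3%
Compound 2, `COc1ccc(-c2cn3ccnc3c(-c3ccc4ncn(C5CCCCC5)c4c3)n2)cc1`: -26.3%
Compound 3, `O=Cc1ccc(-c2cn3ccnc3c(-c3ccc4ncn(C5CCCCC5)c4c3)n2)cc1`: 21.4%

All numbers come from a functional assay on SNB-75 cells (Homo sapiens) for inhibition, read by sulforhodamine B assay, with a stated time of 48 h, tested at 10 uM; on this read-out lower numbers stand for less inhibition and higher numbers for more inhibition at the one concentration tested (going by the name of the read-out). Compound 3 stands highest of the three numbers, but compound 1 lies nearest, and the step of a number 0.1 percentage points higher from compound 1 to compound 3 (within the scatter) gives no ground to order these two. Compound 2 is furthest away, with a number 47.7 percentage points higher from compound 2 to compound 3 (beyond the scatter) separating it from compound 3.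

Compound 4, `c1ccc2c(-c3cn4ccnc4c(-c4ccc5ncn(C6CCCCC6)c5c4)n3)cccc2c1`, differs from compound 3 by naphthalen-1-yl in place of 4-formylphenyl on an aromatic carbon. For the measured compounds named here, three measured steps bear on a change at this position. The steps of a number 47.6 percentage points lower from compound 1 to compound 2 (beyond the scatter) and a number 47.7 percentage points higher from compound 2 to compound 3 (beyond the scatter) show that the group at this carbon can shift the read-out by a large amount in either direction, while a number 0.1 percentage points higher from compound 1 to compound 3 (within the scatter) shows that an exchange there can also leave the number unchanged. Going by the values given here, no measured step covers the naphthalen-1-yl itself or the loss of the single hydrogen-bond acceptor of the 4-formylphenyl, so the direction is uncertain and the spread must be wide.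

For compound 4 a modest fall is expected, a number 16.4 percentage points lower from compound 3 to compound 4 (beyond the scatter), given that in this assay compound 2 gives -26.3% without the formyl. Compound 4 is therefore estimated at 5%, in a range from -30% to 35%.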

Compound 4, a percentage reported as inhibition, at one concentration (the size of the read-out at that concentration, not a potency): 16.5%
Beside the measured number, compound 4's estimate is 11.5 percentage points below it, within the range that was stated.
By their numbers in this assay, from the lowest: compound 2; then compounds 4, 1 and 3 (each within the scatter of the next).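

In this assay, naphthalen-1-yl in place of 4-formylphenyl gives a number 4.9 percentage points lower from compound 3 to compound 4 (within the scatter) and so holds the number within the scatter, even though the entering group has a second six-membered aromatic ring and no hydrogen-bond acceptor. Against bromo the picture is the same, with a number 4.8 percentage points lower from compound 1 to compound 4 (within the scatter) also within the scatter, whereas the 4-methoxyphenyl stands apart, with a number 42.8 percentage points higher from compound 2 to compound 4 (beyond the scatter) as a large step beyond the scatter. Compound 4 lacks the formyl and still does not fall toward compound 2, so among the four compounds the absence of the formyl does not by itself account for the low number of compound 2, and bromo, 4-formylphenyl and naphthalen-1-yl cannot be ordered at this carbon.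

Still open, on these data alone, is whether the low number belongs to the methoxy itself, which a 4-hydroxyphenyl, 4-aminophenyl or 4-carboxyphenyl group on the same carbon of the shared core would help to settle. No evidence at hand explains why compound 2 stands apart from the other three compounds.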